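Phthalimide-alkyl amines: N-ethyl to N-methyl on compound 2

The source may report more compounds than this note shows. Statements on the series, on what has been measured and on what is new or still open speak of the compounds shown alone.

Measured compounds:
compound 1 `CC(C)N1CCN(CCCCN2C(=O)c3ccccc3C2=O)CC1` gives 8900 nM
compound 2 `CCN(CCCCCCN1C(=O)c2ccccc2C1=O)Cc1ccccc1OC` gives 11700 nM
compound 3 `C#CCN(CCCCN1C(=O)c2ccccc2C1=O)Cc1ccccc1` gives 6500 nM

All three were run in an assay on cells for inhibition of Amine oxidase [flavin-containing] B (Homo sapiens), read by fluorescence, with a stated time of 30 min; a lower number here means a stronger inhibitor, a higher number a weaker inhibitor. Compound 2 stands at the numerically highest value of the three, but its gap to compound 1 and its gap to compound 3 both lie within the usual scatter, so the three compounds cannot be separated on these numbers. For the measured compounds named here, no pair among them differs in one place only, so no single-point step has been measured in this set.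

Compound 4 `COc1ccccc1CN(C)CCCCCCN1C(=O)c2ccccc2C1=O` has not yet been measured. It differs from compound 2 as follows: hydrogen in place of methyl on a saturated chain carbon bound to an amine nitrogen. Read one bond further out, the change is ethyl to methyl. Nothing in the measured set shows what a change of this kind does, and the change is small; in this assay no step beyond the scatter is expected in either direction.

Compound 4 is accordingly expected to give about 10000 nM, within roughly 4000 nM to 25000 nM.
The step implied by this estimate, a 1.2-fold lower number from compound 2 to compound 4 (0.07 log units; within the scatter), is expected to sit inside the scatter.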

Compound 4, half-maximal inhibitory concentration: 11300 nM
Compound 4: the middle estimate sits 1.1-fold (0.05 log units) below what was measured; measured number inside the range.
By their numbers in this assay, from the lowest: compounds 3, 1, 4 and 2 (each within the scatter of the next).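

In this assay, for the compounds shown here, ethyl to methyl gives a 1.0-fold lower number from compound 2 to compound 4 (0.02 log units; within the scatter), the first step that can be read at a single place. At this place, on a saturated chain carbon bound to an amine nitrogen, hydrogen in place of methyl therefore does not separate compound 2 from compound 4, and the micromolar-range readings of the pair remain indistinguishable. No supporting measurement bears on this result, so it stands as an observation without an explanation.

Going by these compounds alone, the pair covers only one small change, leaving open whether a larger group such as cyclopropyl or n-butyl, in place of the ethyl of compound 2, would move the number beyond the scatter. A secondary amine carrying hydrogen in place of that ethyl also remains an open comparison with compound 2.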